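Swapping the ring on the amide nitrogen of compound 2

The source may hold more compounds than are shown below. What is called first, only, known or untested is meant among the compounds shown, and "the series" means these compounds.

Values in an ADME assay on MT4 cells (Homo sapiens) for cytotoxicity, read by MTT assay; on this read-out higher numbers stand for lower toxicity in this test and lower numbers for higher toxicity in this test:
compound 1 `Cc1cc(C)cc(S(=O)(=O)c2c(C(=O)NCc3cccc(O)c3)[nH]c3ccc(Cl)cc23)c1`: 27000 nM
compound 2 `Cc1cc(C)cc(S(=O)(=O)c2c(C(=O)NC(C)c3cccc(O)c3)[nH]c3ccc(Cl)cc23)c1`: 16000 nM

Compound 2 cannot be told apart from compound 1 on these numbers. For the measured compounds named here, the only measured step is a 1.7-fold lower number from compound 1 to compound 2 (0.23 log units; within the scatter).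

Compound 3 `Cc1cc(C)cc(S(=O)(=O)c2c(C(=O)NCc3cc(O)ncn3)[nH]c3ccc(Cl)cc23)c1` differs from compound 2 on the amide-type nitrogen: a group of 8 heavy atoms (5 carbon, 2 nitrogen, 1 oxygen; one six-membered aromatic ring with 2 hetero atoms) in place of a group of 9 heavy atoms (8 carbon, 1 oxygen; one six-membered aromatic ring of carbon only), on an amide-type nitrogen. Going by the values given here, the measured step exchanged only a hydrogen for a methyl on the chain, so it is a weak guide, and no measured step changes the ring. In this assay, the expected move is a 1.8-fold higher number from compound 2 to compound 3 (0.24 log units; within the scatter), so no clear shift is foreseen. For compound 3 the estimated value is 28000 nM, with an expected range of 11000 nM to 70000 nM.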

Compound 3, half-maximal cytotoxic concentration: > 53000 nM
Compound 3: only a limit was reported; the forecaster's own chance of this, stated with the estimate: 25%; at least 1.8-fold (0.27 log units) between middle value and limit.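

In this assay, for the compounds shown here, the change of group on the amide-type nitrogen gives an at least 3.3-fold higher number from compound 2 to compound 3 (0.52 log units; beyond the scatter), the first step here to clear the scatter. The cleaner ring swap, without the chain methyl, gives an at least 1.9-fold higher number from compound 1 to compound 3 (0.29 log units; that floor lies within the scatter), so the ring swap alone is not shown to shift the number. Compound 3 has only a limit, not a number: the limit of > 53000 nM in this assay, at which 1 of the 3 values shown sits.

As far as these compounds go, its actual value therefore stays open, and so does the full size of both steps. Also open, from the compounds shown here alone, is what an amine in place of the hydroxyl on the 6-hydroxypyrimidin-4-yl ring would give.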